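The compounds below may be only part of what the source reports. "The series", "measured", "known", "first", "only" and "open" are said of these compounds alone.

Measured in an ADME assay on WEHI13 cells (Mus musculus) for cytotoxicity, read by MTT assay; a lower number here means a stronger inhibitor, a higher number a weaker inhibitor:

- Compound 1 `Cc1c(CN2CCCC2)cc(-c2ccc(Cl)cc2)n1Nc1ccnc2cc(Cl)ccc12`: 2060 nM
- Compound 2 `CCN(CC)Cc1cc(-c2ccccc2)n(Nc2ccnc3cc(Cl)ccc23)c1C`: 4380 nM

Of these two, compound 2 has the higher number, 4380 nM, and so stands as the weaker inhibitor. Compound 1, at 2060 nM, lies lower by a gap beyond the usual scatter.

The next compound to be tested is compound 3 `Cc1c(CN2CCCC2)cc(-c2ccccc2)n1Nc1ccnc2cc(Cl)ccc12`, which differs from compound 2 in one place: pyrrolidin-1-yl in place of diethylamino on a saturated chain carbon bound to an aromatic carbon. Here pyrrolidin-1-yl takes the place of diethylamino on a saturated chain carbon bound to an aromatic carbon. Going by the values given here, no measured pair shows this change in isolation, so the expectation is a tentative one: a small step towards a lower number in this assay, probably not beyond the scatter. The estimated change is a 1.3-fold lower number from compound 2 to compound 3 (0.12 log units; within the scatter). For compound 3 the expected value is 3300 nM, with an estimated range from 1500 nM to 7500 nM.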

Compound 3, half-maximal inhibitory concentration: 3880 nM
Compound 3: the middle estimate sits 1.2-fold (0.07 log units) below what was measured, and the stated range covers the measured number.
By their numbers in this assay, from the lowest: compounds 1, 3 and 2 (each within the scatter of the next, the first and the last beyond it).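

In this assay, the exchange of diethylamino for pyrrolidin-1-yl on a saturated chain carbon bound to an aromatic carbon (a 1.1-fold lower number from compound 2 to compound 3 (0.05 log units; within the scatter)) closes the group into a five-membered ring while keeping its heavy-atom count, and the step stays within the scatter. The second single change, hydrogen in place of chloro on an aromatic carbon (a 1.9-fold higher number from compound 1 to compound 3 (0.27 log units; within the scatter)), also stays within the scatter, so neither change taken alone can be read as a real shift in this assay. Nothing available explains either step.

On these data alone, whether a morpholin-4-yl or a dimethylamino group on the same chain carbon would move the number beyond the scatter remains open. So does the effect of fluoro or methoxy in place of the chloro group.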